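Acetamido for nitro on the shared core

The source may hold more compounds than are shown below. What is called first, only, known or untested is meant among the compounds shown, and "the series" means these compounds.

Going by the values given here, in a functional assay on K562 cells (Homo sapiens) for antiproliferative activity, read by MTT assay, with a stated time of 48 h (a higher number here means a weaker inhibitor, a lower number a stronger inhibitor), compound 1 (`Oc1ccc2cc1Oc1ccc(cc1)CCc1ccc(CN3CCCCC3)c(O)c1-c1ccc(cc1O)CC2`) gives 5880 nM, the only actual number among the three readings so far. Compound 2 (`CCCCN(CCCC)Cc1cc2cc(c1O)Oc1ccc(cc1)CCc1ccc(CN(CCCC)CCCC)c(O)c1-c1ccc(cc1O)CC2`) reads > 20000 nM, which is a limit of the assay. Compound 3 (`O=[N+]([O-])c1cc2cc(c1O)Oc1ccc(cc1)CCc1cccc(O)c1-c1ccc(cc1O)CC2`) reads > 20000 nM, also a limit and not a number. Compound 3 therefore stands at the limit of > 20000 nM in this assay, at which 2 of the 3 values shown sit.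

Compound 4 (`CC(=O)Nc1cc2cc(c1O)Oc1ccc(cc1)CCc1cccc(O)c1-c1ccc(cc1O)CC2`) has acetamido in place of nitro on an aromatic carbon, ortho to a hydroxy group: acetamido in place of nitro on an aromatic carbon. Among the compounds with values here, no measured pair shows what a change of this kind does.

The expectation rests on compound 3, whose reading of > 20000 nM is a limit. The estimated change is an at least 1.1-fold lower number from compound 3 to compound 4 (0.04 log units; that floor lies within the scatter), and no step beyond the scatter is expected in this assay, in either direction. For compound 4 the estimated value is 18000 nM, with an expected range from 8000 nM to 40000 nM.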

Compound 4, half-maximal inhibitory concentration: > 20000 nM
Compound 4: no number, only a limit; the forecaster's own chance of this, stated with the estimate: 55%; middle value at least 1.1-fold (0.04 log units) from the limit.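

In this assay compound 4 gives > 20000 nM, a limit and not a number. Compound 3 also stands at a limit, and no step can be read between compound 3 and compound 4. The compounds shown leave open what acetamido in place of nitro does on the shared core.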